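Halogen swap on the benzyl arm of compound 2

The compounds below may be only part of what the source reports. "The series", "measured", "known", "first", "only" and "open" are said of these compounds alone.

Compound 2 `COc1ccc(C(=O)Nc2ncc(Cc3cc(Cl)cc(Cl)c3)s2)cc1OCCO` gives the lowest of the two numbers measured in an assay on microsomes for inhibition of acyl-CoA desaturase 1 (Mus musculus), with a stated time of 60 min (on this read-out lower numbers stand for stronger inhibition and higher numbers for weaker inhibition), at 0.7 nM. Compound 1 `COc1ccc(C(=O)Nc2ncc(Cc3cccc(C(C)(C)C)c3)s2)cc1OCCO` gives 1310 nM in this assay. Among the compounds with values here, the only measured step, a 1900-fold lower number from compound 1 to compound 2 (3.27 log units; beyond the scatter), shows that the group on the saturated chain carbon bound to an aromatic carbon moves this assay strongly. Compound 3 `COc1ccc(C(=O)Nc2ncc(Cc3cc(F)cc(F)c3)s2)cc1OCCO` carries 3,5-difluorophenyl in place of 3,5-dichlorophenyl on a saturated chain carbon bound to an aromatic carbon. Within the data shown here, no measured step exchanges one halogen pair for another, so the direction rests only on the weight of that single step. Compound 3 is expected to give a moderately higher number, an 11-fold higher number from compound 2 to compound 3 (1.06 log units; beyond the scatter), estimated at 8 nM within a range from 1.5 nM to 50 nM.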

Compound 3, half-maximal inhibitory concentration: 0.1 nM
Estimate against measurement, compound 3: 80-fold (1.90 log units) above; measured number outside the range, below it.
By their numbers in this assay, from the lowest: compound 3; then compound 2; then compound 1.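

In this assay the step of a 7.0-fold lower number from compound 2 to compound 3 (0.85 log units; beyond the scatter) shows that this place on the saturated chain carbon bound to an aromatic carbon takes 3,5-difluorophenyl as well as 3,5-dichlorophenyl, with the number lower for the fluorine pair. Set against 3-(tert-butyl)phenyl, the step of a 13000-fold lower number from compound 1 to compound 3 (4.12 log units; beyond the scatter) is wider still than the one seen with the chlorine pair. No measurement at hand accounts for this order of groups.

Still open, going by these compounds, is whether a single fluorine, a trifluoromethyl group or a methoxy group on this phenyl ring would keep the number as low. Also open, on these data alone, is whether a pyridine ring could take the place of the phenyl ring.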